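Cytotoxicity notes: phenoxy for nitrophenyl on the sulfur chain

The source may report more compounds than this note shows. Statements on the series, on what has been measured and on what is new or still open speak of the compounds shown alone.

Compound 2 `Cc1cc(C)cc(Cc2nc(SCCc3ccc([N+](=O)[O-])cc3)[nH]c(=O)c2I)c1` gives the highest of the three numbers in an ADME assay on HepG2 2.2.15 cells (Homo sapiens) for cytotoxicity, read by MTT assay, with a stated time of 72 h (on this read-out higher numbers stand for lower toxicity in this test and lower numbers for higher toxicity in this test), with 66600 nM; compound 1 `O=c1[nH]c(SCc2ccc([N+](=O)[O-])cc2)nc(Cc2ccccc2)c1I` gives 52700 nM and compound 3 `Cc1cc(C)cc(Cc2nc(SCc3ccc([N+](=O)[O-])cc3)[nH]c(=O)c2I)c1` gives 39000 nM, so all three sit within the scatter of one another. Among the compounds with values here, the one measured single-point step, a 1.4-fold lower number from compound 1 to compound 3 (0.13 log units; within the scatter), concerns the benzyl end of the core and not the sulfur chain. Compound 4 `Cc1cc(C)cc(Cc2nc(SCCOc3ccccc3)[nH]c(=O)c2I)c1` differs from compound 2 by phenoxy in place of 4-nitrophenyl on a saturated chain carbon, two bonds along the chain from a sulfur. Within the data shown here, no measured step bears on this change directly, and the three numbers give no sign of movement in either direction. Compound 4 is therefore expected to stay close to compound 2, with a 1.1-fold lower number from compound 2 to compound 4 (0.05 log units; within the scatter) meaning no step beyond the scatter. The estimate for compound 4 in this assay is 60000 nM, in the range 30000 nM to 120000 nM.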

Compound 4, half-maximal cytotoxic concentration: > 100000 nM
Compound 4 ended at the assay's limit (the forecaster's own chance of this, stated with the estimate: 10%); at least 1.6-fold (0.22 log units) between middle value and limit.
By their numbers in this assay, from the lowest: compounds 3, 1 and 2 (each within the scatter of the next). At a limit, above all of these: compound 4.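

In this assay compound 4 gives > 100000 nM, which is a limit of the assay and not a number. The change reads as an at least 1.5-fold higher number from compound 2 to compound 4 (0.17 log units; that floor lies within the scatter), while the wider comparison gives an at least 2.5-fold higher number from compound 3 to compound 4 (0.40 log units; beyond the scatter). The sulfur chain is thus the first place in this series where a change gives a step beyond the scatter, and that step points to lower toxicity in this test.

As far as these compounds go, the true size of the step from the 4-nitrophenyl compound remains open. Also open, from the compounds shown here alone, is how an amine on the phenoxy ring or a longer chain would read here.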